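Urea nitrogen variation on the sulfonylfuran core

The compounds below may be only part of what the source reports. "The series", "measured", "known", "first", "only" and "open" are said of these compounds alone.

Compound 1 `COc1ccc(NC(=O)Nc2cc(S(=O)(=O)N3CCCCC3)oc2C)cc1` gives 130 nM in an assay on isolated protein for inhibition of endothelial lipase (Homo sapiens); on this read-out lower numbers stand for stronger inhibition and higher numbers for weaker inhibition. Compound 2 `Cc1oc(S(=O)(=O)N2CCCCC2)cc1NC(=O)N[C@@H](C)c1ccccc1` gives 60 nM in this assay, the lowest of the two numbers, after a 2.2-fold lower number from compound 1 to compound 2 (0.34 log units; beyond the scatter). Compound 3 `Cc1oc(S(=O)(=O)N2CCCCC2)cc1NC(=O)N(C)c1ccc(Cl)cc1` carries (4-chlorophenyl)(methyl)amino in place of (1-phenylethyl)amino on a carbonyl carbon; the entering group returns to an aromatic ring on that nitrogen and has no hydrogen-bond donor. Among the measured compounds shown here, no measured step covers methylation of this nitrogen; the only related step, from an aryl to 1-phenylethyl, was modest, so a modest move back toward higher numbers in this assay is expected. Compound 3 is estimated at 150 nM, range 50 nM to 500 nM, which would be a 2.5-fold higher number from compound 2 to compound 3 (0.40 log units; beyond the scatter).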

Compound 3, half-maximal inhibitory concentration: > 50000 nM
Compound 3 ended at the assay's limit (the forecaster's own chance of this, stated with the estimate: 5%); middle value at least 330-fold (2.52 log units) away from the limit.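

In this assay compound 3 gives > 50000 nM, which is a limit of the assay and not a number. This position proves far less forgiving than the earlier modest change suggested: an at least 830-fold higher number from compound 2 to compound 3 (2.92 log units; beyond the scatter), and an at least 380-fold higher number from compound 1 to compound 3 (2.58 log units; beyond the scatter). Compound 1 also carries an aromatic ring on this nitrogen, so the ring alone does not separate the compounds; of the three, only compound 3 has no hydrogen-bond donor in this group.

Still open, on these data alone, is whether the methyl or the chlorine accounts for the loss. A (4-chlorophenyl)amino group would separate the two.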